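The compounds below may be only part of what the source reports. "The series", "measured", "known", "first", "only" and "open" are said of these compounds alone.

Measured compounds:
compound 1 `CC(C)Cn1nnc2c(Br)cccc21` – 140 nM
compound 2 `CCCn1nnc2c(Br)cccc21` – 270 nM

For the measured compounds named here, in a functional assay on cells for positive allosteric modulation of metabotropic glutamate receptor 2 (Homo sapiens), read by fluorescence and calcium flux, with a stated time of 30 min (a lower number here means that less compound is needed, a higher number that more compound is needed for the effect), compound 2 gives 270 nM and stands at the highest of the two numbers so far; its nearest neighbour is compound 1, which in this assay gives 140 nM. The step of a 1.9-fold higher number from compound 1 to compound 2 (0.29 log units; within the scatter) is within the scatter, so the two compounds cannot be ordered on these numbers.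

Compound 3 `CCn1nnc2c(Br)cccc21` is not yet measured. It differs from compound 2 by hydrogen in place of methyl on a saturated chain carbon, two bonds along the chain from an aromatic nitrogen; read one bond further out, propyl becomes ethyl on the nitrogen of the shared core. Going by the values given here, the only step that bears on this is a 1.9-fold higher number from compound 1 to compound 2 (0.29 log units; within the scatter), which also removed a methyl from the saturated chain, though from the branch rather than from the chain end, and gave a higher number that stayed within the scatter. On that basis the expected step of a 1.7-fold higher number from compound 2 to compound 3 (0.22 log units; within the scatter) for compound 3 is a further, modest rise in the number, with no confidence that it leaves the scatter. In this assay compound 3 is therefore estimated at 450 nM, with a range from 180 nM to 1200 nM.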

Compound 3, half-maximal effective concentration: 2240 nM
Compound 3: the middle estimate sits 5.0-fold (0.70 log units) below what was measured; the measured number lies above the stated range.
By their numbers in this assay, from the lowest: compounds 1 and 2 (each within the scatter of the next); then compound 3.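

In this assay, cutting propyl back to ethyl on the shared core gives an 8.3-fold higher number from compound 2 to compound 3 (0.92 log units; beyond the scatter) and so lies beyond the scatter, which the earlier removal of a methyl from the branch did not do; the methyl two bonds along the chain from an aromatic nitrogen therefore counts in this series. The full change on the saturated chain carbon bound to an aromatic nitrogen, methyl in place of isopropyl, gives a 16-fold higher number from compound 1 to compound 3 (1.20 log units; beyond the scatter) and is a large step, so among these three compounds only the ethyl compound stands apart, while compound 1 and compound 2 remain within the scatter of each other. Nothing available explains why removing this one methyl has so much more weight than removing the one on the branch.

Open, as far as these compounds go, is how far the chain can grow before the number changes again, for example with butyl or a longer chain, and whether a chain ending in a hydroxyl or an amine would be tolerated at this place. Also open, from the compounds shown here alone, is whether the same chain dependence holds when the bromine on the core gives way to chlorine or a nitrile.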